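Swapping an aryl for a benzyl on the piperazine nitrogen

The source may hold more compounds than are shown below. What is called first, only, known or untested is meant among the compounds shown, and "the series" means these compounds.

Measured so far:
- compound 1, `Nc1ccccc1NC(=O)c1ccc(CSC(=S)N2CCN(c3ccc(Cl)cc3)CC2)cc1`: 51.2%
- compound 2, `N#Cc1ccc(N2CCN(C(=S)SCc3ccc(C(=O)Nc4ccccc4N)cc3)CC2)cc1`: 71.6%
- compound 3, `Nc1ccccc1NC(=O)c1ccc(CSC(=S)N2CCN(c3ccccc3F)CC2)cc1`: 17.5%

In a functional assay on HeLa cells (Homo sapiens) for antiproliferative activity, read by CCK-8 assay, with a stated time of 72 h, tested at 2 uM (on this read-out lower numbers stand for a weaker effect and higher numbers for a stronger effect at the one concentration tested), compound 3 stands lowest of the three, its steps to both others lying beyond the scatter. The unmeasured compound 4, `Nc1ccccc1NC(=O)c1ccc(CSC(=S)N2CCN(Cc3ccccc3)CC2)cc1`, differs from compound 3 by benzyl in place of 2-fluorophenyl on an amine nitrogen in a ring. Among the measured compounds shown here, two measured steps bear on this place: a number 33.7 percentage points lower from compound 1 to compound 3 (beyond the scatter) and a number 54.1 percentage points lower from compound 2 to compound 3 (beyond the scatter), both showing that the 2-fluorophenyl group goes with the weakest effect. For the measured compounds named here, replacing it with benzyl is therefore expected to move the number upward, probably by a modest to large amount, though no step with a benzyl is known. Compound 4 is estimated at 45%, within 20% to 70%, which would mean an expected step of a number 27.5 percentage points higher from compound 3 to compound 4 (beyond the scatter).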

Compound 4, a percentage reported as inhibition, at one concentration (the size of the read-out at that concentration, not a potency): 20.6%
Compound 4: middle estimate off by 24.4 percentage points, on the high side, and the stated range covers the measured number.
By their numbers in this assay, from the lowest: compounds 3 and 4 (each within the scatter of the next); then compound 1; then compound 2.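

In this assay, a number 3.1 percentage points higher from compound 3 to compound 4 (within the scatter) means that benzyl and 2-fluorophenyl cannot be told apart on this amine nitrogen. Benzyl falls well short of the two groups with a substituent at the 4-position of the phenyl ring, with a number 30.6 percentage points lower from compound 1 to compound 4 (beyond the scatter) for 4-chlorophenyl and a number 51 percentage points lower from compound 2 to compound 4 (beyond the scatter) for 4-cyanophenyl on the same nitrogen. No evidence at hand explains these differences. Still open, on these data alone, is whether plain phenyl would match 2-fluorophenyl and benzyl. Also open, as far as these compounds go, is whether 4-cyanobenzyl, or a longer chain such as 2-phenylethyl, would reach the number of compound 2.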